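A few compounds are considered here, and "the series" means these few. Any claim that something is new, unique, unknown or untested is made for them only; others in the source may bear on it.

Compound 3 `O=C1C2=C(C(=O)c3ncccc31)C1(CS2)NC(=O)N(c2ccc(Cl)cc2)C1=O` gives 10 nM in a functional assay on CCRF-SB cells (Homo sapiens) for antiproliferative activity, read by MTT assay, with a stated time of 96 h; on this read-out higher numbers stand for weaker inhibition and lower numbers for stronger inhibition. Among the three compounds measured it holds the second highest number: compound 1 `CCCc1ccc(N2C(=O)NC3(CSC4=C3C(=O)c3ncccc3C4=O)C2=O)cc1` gives 2 nM, a gap described by a 5.0-fold higher number from compound 1 to compound 3 (0.70 log units; beyond the scatter), while compound 2 `O=C1NC(=O)C2(CSC3=C2C(=O)c2ncccc2C3=O)N1` gives 150 nM, the gap being a 15-fold lower number from compound 2 to compound 3 (1.18 log units; beyond the scatter). The step of a 75-fold higher number from compound 1 to compound 2 (1.88 log units; beyond the scatter) shows the same large effect of the group on the amide-type nitrogen in a ring.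

Compound 4 `O=C1C2=C(C(=O)c3ncccc31)C1(CS2)NC(=O)N(c2ccc([N+](=O)[O-])cc2)C1=O` differs from compound 3 by nitro in place of chloro on an aromatic carbon. Within the data shown here, no measured pair changes a chloro to a nitro, so the only step that bears on a change at this aromatic carbon is the modest one from propyl to chloro, a 5.0-fold higher number from compound 1 to compound 3 (0.70 log units; beyond the scatter); the large steps to compound 2 concern the whole aryl group and not its substituent. A change of this kind is therefore expected to move the number only modestly, if at all beyond the scatter, with the direction uncertain, and compound 4 is estimated at 15 nM, between 4 nM and 60 nM, a step of a 1.5-fold higher number from compound 3 to compound 4 (0.18 log units; within the scatter).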

Compound 4, half-maximal inhibitory concentration: 2 nM
Compound 4: the middle estimate sits 7.5-fold (0.88 log units) above what was measured, and the stated range ends above it.
By their numbers in this assay, from the lowest: compounds 1 and 4 (each within the scatter of the next); then compound 3; then compound 2.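

Nitro in place of chloro gives a 5.0-fold lower number from compound 3 to compound 4 (0.70 log units; beyond the scatter) and so shows that a second substituent on this aromatic carbon also moves the number beyond the scatter, this time downward. Propyl and nitro are not separated, with no change at the digits printed from compound 1 to compound 4 (within the scatter) as the step between them, so among these three substituents it is chloro that stands apart with the higher number. Adding the whole 4-nitrophenyl group to the amide-type nitrogen in a ring gives a 75-fold lower number from compound 2 to compound 4 (1.88 log units; beyond the scatter) as the step, which is larger than the step measured for 4-chlorophenyl. As far as these compounds go, whether an amine, a carboxylic acid or a longer chain on this aromatic carbon would go with propyl and nitro or with chloro remains open. Nothing given here explains why chloro differs from the other two.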